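Expecting compound 4 after an amine swap

A few compounds are considered here, and "the series" means these few. Any claim that something is new, unique, unknown or untested is made for them only; others in the source may bear on it.

In a functional assay (aorta) with Rattus norvegicus as the target (on this read-out lower numbers stand for stronger inhibition and higher numbers for weaker inhibition), compound 3 (`COc1ccc(CNCCCOc2ccc(S(=O)(=O)c3c(C(C)C)cn4ccccc34)cc2)cc1OC`) gives 13 nM. Compound 2 (`CCCCN(CCCC)CCCCOc1ccc(S(=O)(=O)c2c(C(C)C)cn3ccccc23)cc1`) gives 20.2 nM, which is level with compound 3 within the scatter, while compound 1 (`CCN(CC)CCCOc1ccc(S(=O)(=O)c2c(C)cn3ccccc23)cc1`) stands far higher at 3390 nM.

Compound 4 (`CCN(CC)CCCOc1ccc(S(=O)(=O)c2c(C(C)C)cn3ccccc23)cc1`) changes one place of compound 3: diethylamino in place of (3,4-dimethoxybenzyl)amino on a saturated chain carbon, three bonds along the chain from an oxygen on an aromatic ring. Diethylamino takes the place of (3,4-dimethoxybenzyl)amino on a saturated chain carbon, three bonds along the chain from an oxygen on an aromatic ring.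

For the measured compounds named here, one measured step bears directly on this: a 1.6-fold lower number from compound 2 to compound 3 (0.19 log units; within the scatter), a different amine exchange that stayed within the scatter. Compound 1 also carries diethylamino, but its 3390 nM comes with methyl where compound 4 has isopropyl, so it cannot show what the amine alone does. The data therefore suggest only a small move towards a higher number. The expected step is a 2.3-fold higher number from compound 3 to compound 4 (0.36 log units; beyond the scatter), at about the edge of the scatter. For compound 4 the estimated value is 30 nM, with an expected range of 8 nM to 150 nM.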

Compound 4, half-maximal inhibitory concentration: 228 nM
Estimate against measurement, compound 4: 7.6-fold (0.88 log units) below; the whole stated range lies below it.
By their numbers in this assay, from the lowest: compounds 3 and 2 (each within the scatter of the next); then compound 4; then compound 1.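

In this assay, the choice of amine at this chain position turns out to matter a great deal: diethylamino in place of (3,4-dimethoxybenzyl)amino gives an 18-fold higher number from compound 3 to compound 4 (1.24 log units; beyond the scatter), and diethylamino in place of (dibutylamino)methyl gives an 11-fold higher number from compound 2 to compound 4 (1.05 log units; beyond the scatter), so the level pair of compound 2 and compound 3 had hidden how much weaker an amine here can be. With diethylamino held fixed, the other position counts too, as isopropyl in place of methyl on an aromatic carbon gives a 15-fold lower number from compound 1 to compound 4 (1.17 log units; beyond the scatter). Nothing measured here explains why diethylamino stands apart from the other two amines.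

On these data alone, whether other amines on this chain, such as a pyrrolidine or a morpholine, would behave like diethylamino remains open. As far as these compounds go, it is also open whether methyl in place of isopropyl would cost as much alongside the (3,4-dimethoxybenzyl)amino group.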